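Working notes: exchanging the hydroxycarbamoyl chain

This account rests on a few compounds, and the source may have more. Where it says the series, first, only, none or still open, it means among the compounds named here.

In a functional assay on A549 cells (Homo sapiens) for inhibition, read by MTT assay, with a stated time of 72 h (a higher number here means a weaker inhibitor, a lower number a stronger inhibitor), compound 1 `O=C(CCCCCCCN(Cc1ccc(F)cc1)c1ncc(C(=O)NCCCn2ccnc2)s1)NO` gives 6600 nM and compound 2 `CC(C)CCN(CCCCCC(=O)NO)c1ncc(C(=O)NCCCn2ccnc2)s1` gives 13000 nM. These two values lie within the scatter of each other, so compound 1 stands level with compound 2 and the series shows no separation so far. The next compound is compound 3 `O=C(/C=C/c1ccc(CN(Cc2ccc(F)cc2)c2ncc(C(=O)NCCCn3ccnc3)s2)cc1)NO`, which carries 4-(2-(hydroxycarbamoyl)ethenyl)phenyl in place of 6-(hydroxycarbamoyl)hexyl on a saturated chain carbon bound to a nitrogen on an aromatic ring. Going by the values given here, no measured pair isolates a change of this kind, so the forecast has little to rest on. In this assay, a modest move towards a lower number is expected, although a result within the scatter of compound 1 remains quite possible. The estimated size is a 2.2-fold lower number from compound 1 to compound 3 (0.34 log units; beyond the scatter). For compound 3 the expected value is 3000 nM, with an estimated range of 800 nM to 10000 nM.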

Compound 3, half-maximal inhibitory concentration: 2700 nM
Compound 3: middle estimate off by 1.1-fold (0.05 log units), on the high side, and the stated range covers the measured number.
By their numbers in this assay, from the lowest: compound 3; then compounds 1 and 2 (each within the scatter of the next).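

Going by these compounds alone, on a saturated chain carbon bound to a nitrogen on an aromatic ring, the hydroxycarbamoyl-bearing group can be exchanged with a modest effect on the read-out: in this assay, 4-(2-(hydroxycarbamoyl)ethenyl)phenyl in place of 6-(hydroxycarbamoyl)hexyl gives a 2.4-fold lower number from compound 1 to compound 3 (0.39 log units; beyond the scatter), the first step beyond the scatter. The entering group adds one six-membered aromatic ring of carbon only and a further double bond outside aromatic rings, while both groups have 2 hydrogen-bond donors and 2 hydrogen-bond acceptors. Nothing available explains the lower number.

The compounds shown leave open whether the ring or the ethenyl link carries the step, a question that 4-(hydroxycarbamoyl)phenyl would address. Also open, as far as these compounds go, is whether the step would persist with a carboxylic acid in place of the hydroxycarbamoyl group.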